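Trimming the hydroxymethyl end from compound 3

This account rests on a few compounds, and the source may have more. Where it says the series, first, only, none or still open, it means among the compounds named here.

Going by the values given here, in an ADME assay on RAW264.7 cells (Mus musculus) for cytotoxicity, read by MTT assay, with a stated time of 24 h (a lower number here means that less compound is tolerated, a higher number that more compound is tolerated), compound 3 (`CC/C=C\C[C@H]1C(=O)C=C[C@H]1CC(=O)OCCOCCO`) gives 166 uM, the highest of the three numbers so far. Compound 1 (`CC/C=C\C[C@H]1C(=O)C=C[C@H]1CC(=O)OCCCC`) gives 31 uM, and compound 2 (`CC/C=C\C[C@H]1C(=O)C=C[C@H]1CC(=O)OCc1ccccc1`) gives 31 uM. Compound 4 (`CC/C=C\C[C@H]1C(=O)C=C[C@H]1CC(=O)OCCOC`) differs from compound 3 in one place: hydrogen in place of hydroxymethyl on a saturated chain carbon bound to an oxygen on a saturated carbon, with hydrogen in place of hydroxymethyl on a saturated chain carbon bound to an oxygen on a saturated carbon. Among the compounds with values here, two measured steps bear on this change: a 5.4-fold higher number from compound 1 to compound 3 (0.73 log units; beyond the scatter), and a 5.4-fold higher number from compound 2 to compound 3 (0.73 log units; beyond the scatter). Neither shows how much of that difference remains with methoxy in place of 2-hydroxyethoxy, so a partial return towards the lower numbers is expected. The expected step is a 2.4-fold lower number from compound 3 to compound 4 (0.38 log units; beyond the scatter). For compound 4 the estimated value is 70 uM, with an expected range from 30 uM to 160 uM.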

Compound 4, half-maximal toxic concentration: 160 uM
Compound 4: middle estimate off by 2.3-fold (0.36 log units), on the low side; the range from low to high includes it.
By their numbers in this assay, from the lowest: compounds 1 and 2 (each within the scatter of the next); then compounds 4 and 3 (each within the scatter of the next).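

In this assay, hydrogen in place of hydroxymethyl gives a 1.0-fold lower number from compound 3 to compound 4 (0.02 log units; within the scatter), so the higher number does not depend on the hydroxymethyl end. The shorter methoxy chain keeps the whole gain over the other two compounds, with a 5.2-fold higher number from compound 2 to compound 4 (0.71 log units; beyond the scatter) and a 5.2-fold higher number from compound 1 to compound 4 (0.71 log units; beyond the scatter). Nothing measured here explains what holds the number up. Going by these compounds, whether an amine, a carboxylic acid or a longer chain in place of methoxy would keep the number this high remains open.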